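Swapping a Fluorophenoxy Ether for a Fluorophenethyl Chain

The compounds below may be only part of what the source reports. "The series", "measured", "known", "first", "only" and "open" are said of these compounds alone.

Compound 1 `Cn1nc(-c2nnc(SCc3ccc(C(F)(F)F)cc3)o2)cc1-c1ccc(C(F)(F)F)cc1` gives 15500 nM in a functional assay on MCF7 cells (Homo sapiens) for cytotoxicity, read by MTT assay, with a stated time of 24 h; on this read-out lower numbers stand for stronger inhibition and higher numbers for weaker inhibition.
Compound 2 `Cn1nc(-c2ccc(C(F)(F)F)cc2)cc1-c1nnc(S)o1` reaches only the limit > 100000 nM in this assay.
Compound 3 `Cn1nc(-c2ccc(C(F)(F)F)cc2)cc1-c1nnc(SCCOc2ccccc2F)o1` gives 33300 nM in this assay.

Among the two numbers that are not limits, compound 3 holds the higher one, and its gap to compound 1 lies beyond the scatter. Among the compounds with values here, the one measured step, an at least 3.0-fold lower number from compound 2 to compound 3 (0.47 log units; beyond the scatter), shows that attaching a chain to the sulfur moves the read-out; the value of compound 2 is a limit, (the limit of > 100000 nM in this assay, at which 1 of the 3 values shown sits), so only the lower bound of that step is known.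

Compound 4 `Cn1nc(-c2ccc(C(F)(F)F)cc2)cc1-c1nnc(SCCc2ccc(F)cc2)o1` differs from compound 3 in one place: 4-fluorophenyl in place of 2-fluorophenoxy on a saturated chain carbon, two bonds along the chain from a sulfur. Within the data shown here, no measured step changes the group at the end of the chain while keeping the rest fixed, so the closest guide is the size of an at least 3.0-fold lower number from compound 2 to compound 3 (0.47 log units; beyond the scatter), which concerns the whole chain rather than its tip. From this, no more than a small step in this assay is expected, in either direction, and most likely none beyond the scatter.

Compound 4 is therefore estimated at 25000 nM, with a range from 10000 nM to 60000 nM. The step from compound 3 to compound 4 is expected to be a 1.3-fold lower number from compound 3 to compound 4 (0.12 log units; within the scatter).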

Compound 4, half-maximal inhibitory concentration: 45400 nM
For compound 4 the middle estimate is 1.8-fold (0.26 log units) below the measured one; low and high end bracket the measured number.
By their numbers in this assay, from the lowest: compound 1; then compounds 3 and 4 (each within the scatter of the next). At a limit, above all of these: compound 2.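

Within the data shown here, the change of 2-fluorophenoxy to 4-fluorophenyl on a saturated chain carbon, two bonds along the chain from a sulfur, is the first measured change at the tip of the chain, and it stays within the scatter in this assay (a 1.4-fold higher number from compound 3 to compound 4 (0.13 log units; within the scatter)). The entering group carries no hydrogen-bond acceptor where the leaving group carries one, and compounds 3 and 4 still cannot be told apart on this read-out. A second chain on the sulfur also gives a step beyond the scatter (an at least 2.2-fold lower number from compound 2 to compound 4 (0.34 log units; beyond the scatter)), so the earlier step is no longer the only one of its kind, although the value of compound 2 is a limit and this step too is only a bound: the limit of > 100000 nM in this assay, at which 1 of the 4 values shown sits.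

The swap alters the link in the chain and the place of the fluorine in one move, so the compounds shown do not separate the two, and a 2-(2-fluorophenyl)ethyl or a 2-(4-fluorophenoxy)ethyl group would be needed to do so. They also leave open how an amine or a carboxylic acid at the end of the chain, or a longer chain, would read in this assay.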